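Ethylamino to butylamino: working notes on cytotoxicity

The compounds below may be only part of what the source reports. "The series", "measured", "known", "first", "only" and "open" are said of these compounds alone.

Measured in an ADME assay on HaCaT cells (Homo sapiens) for cytotoxicity, read by MTT assay, with a stated time of 72 h; on this read-out higher numbers stand for weaker inhibition and lower numbers for stronger inhibition:
- compound 1 `CCCCCCCCNC1=CC(=O)C=C(C[C@]2(C)[C@@H](C)CC[C@]3(C)C(C)=CCC[C@@H]23)C1=O` gives 17000 nM
- compound 2 `CCNC1=CC(=O)C(C(C)(C)C)=CC1=O` gives 75000 nM

Compound 2 (75000 nM) holds the higher of the two numbers, and compound 1 (17000 nM) lies lower, by a gap beyond the scatter. Compound 3 `CCCCNC1=CC(=O)C(C(C)(C)C)=CC1=O` has not been measured in this assay and differs from compound 2 by ethyl in place of hydrogen on a saturated chain carbon, two bonds along the chain from an amine nitrogen. Within the data shown here, no measured pair isolates this change, so the expectation is loose. Among the measured compounds shown here, the only lower number belongs to compound 1 (17000 nM), which is weak support for the direction. The estimated 1.8-fold lower number from compound 2 to compound 3 (0.25 log units; within the scatter) is a modest move toward a lower number, near the edge of the scatter. The expected value for compound 3 is 42000 nM, with an estimated range from 18000 nM to 90000 nM.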

Compound 3, half-maximal inhibitory concentration: > 100000 nM
Compound 3 was reported as a limit; the forecaster's own chance of this, stated with the estimate: 8%; middle value at least 2.3-fold (0.37 log units) away from the limit.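

In this assay compound 3 gives > 100000 nM, which is a limit of the assay and not a number: the limit of > 100000 nM in this assay, at which 1 of the 3 values shown sits.

The change from ethylamino to butylamino now has a reading of its own, an at least 1.3-fold higher number from compound 2 to compound 3 (0.12 log units; that floor lies within the scatter), so the floor alone does not separate the two compounds. Even so, on a saturated chain carbon, two bonds along the chain from an amine nitrogen, ethyl in place of hydrogen gives no sign of a move toward a lower number, which the earlier compounds could not show.

On these data alone, the true value of compound 3 stays open, and with it the size of the step. Also open, as far as these compounds go, is how a propylamino group, or a longer chain such as hexylamino, would read on the shared core.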